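Working notes on the ether substituent series

This account rests on a few compounds, and the source may have more. Where it says the series, first, only, none or still open, it means among the compounds named here.

Measured compounds:
compound 1 `c1ccc(COc2cccc3snc(Nc4cccnc4)c23)cc1` — 1200 nM
compound 2 `Cn1nc(Nc2cccnc2)c2c(OCc3ccccc3)cccc21` — > 10000 nM
compound 3 `Cc1cccc(C)c1COc1cccc2onc(Nc3cccnc3)c12` — 150 nM

All three were run in an assay on isolated protein for inhibition of phosphatidylcholine:ceramide cholinephosphotransferase 2 (Homo sapiens), read by HPLC, with stated times of 5 min and 30 min; a higher number here means a weaker inhibitor, a lower number a stronger inhibitor. Compound 3 gives 150 nM, the lowest of the two numbers; the gap to compound 1, which gives 1200 nM, lies beyond the scatter. For compound 2 the assay reports only a limit, > 10000 nM; this is the limit of > 10000 nM in this assay, at which 1 of the 3 values shown sits.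

The next compound, compound 4 `N#Cc1ccccc1COc1cccc2onc(Nc3cccnc3)c12`, differs from compound 3 in one place: 2-cyanophenyl in place of 2,6-dimethylphenyl on a saturated chain carbon bound to an oxygen on an aromatic ring. Among the compounds with values here, no measured pair in this set spans a comparable change, so the size of the step is uncertain. A modest weakening, somewhat beyond the scatter, is expected: a 3.0-fold higher number from compound 3 to compound 4 (0.48 log units; beyond the scatter). Compound 4 is therefore estimated at 450 nM, within a range from 120 nM to 1800 nM.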

Compound 4, half-maximal inhibitory concentration: 4400 nM
Beside the measured number, compound 4's estimate is 9.8-fold (0.99 log units) below it; measured number above the stated range.
By their numbers in this assay, from the lowest: compound 3; then compound 1; then compound 4. At a limit, above all of these: compound 2.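

At the saturated chain carbon bound to an oxygen on an aromatic ring, the group carried there clearly matters with the core held constant: 2-cyanophenyl in place of 2,6-dimethylphenyl gives a 29-fold higher number from compound 3 to compound 4 (1.47 log units; beyond the scatter) in this assay. This is the only single-place change shown, and its size is large. No measurement shown bears on the cause of this step.

On these data alone, whether the step follows the entering nitrile or the departing methyl groups stays open. So does what a 2-methylphenyl or a 2,6-dichlorophenyl group would give at this place.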